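A few compounds are considered here, and "the series" means these few. Any claim that something is new, unique, unknown or untested is made for them only; others in the source may bear on it.

Among the measured compounds shown here, compound 1, `C=C(Br)C(=O)Nc1ccc(/C=C2\SC(=O)N(Cc3ccccc3)C2=O)cc1`, is the only member of this small set with a numeric result: in a functional assay on HeLa cells (Homo sapiens) for cytotoxicity, read by cell counting, with a stated time of 4 days (a higher number here means a weaker inhibitor, a lower number a stronger inhibitor), compound 1 gives 1000 nM. Compound 2, `Nc1cccc(/C=C2\SC(=O)N(Cc3ccccc3)C2=O)c1`, returns only a limit of the assay in this assay, > 250000 nM, and no number behind it. On the numbers shown, compound 1 therefore stands alone, and the limit of > 250000 nM in this assay, at which 1 of the 2 values shown sits, marks where the other entry sits. Compound 3, `C=C(Br)C(=O)Nc1ccc(/C=C2\SC(=O)N(Cc3cccc(F)c3)C2=O)cc1`, differs from compound 1 by fluoro in place of hydrogen on an aromatic carbon; seen one bond further out, the benzyl on the shared core becomes 3-fluorobenzyl. For the measured compounds named here, no measured pair in this set carries that change, so its effect in this assay can only be anticipated. A fluoro on this aromatic carbon is expected to leave the result of compound 1 essentially where it is, so the expected step is no change at the digits printed from compound 1 to compound 3 (within the scatter), not beyond the usual scatter. Compound 3 is accordingly estimated at 1000 nM, with a likely range from 400 nM to 2500 nM.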

Compound 3, half-maximal inhibitory concentration: 5900 nM
Compound 3: the middle estimate sits 5.9-fold (0.77 log units) below what was measured, outside the stated range (above it).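

On the benzyl of the shared core, the change to 3-fluorobenzyl gives a 5.9-fold higher number from compound 1 to compound 3 (0.77 log units; beyond the scatter) in this assay. This part of the molecule is therefore not indifferent to substitution: a single fluoro on an aromatic carbon, meta to a large group, moves the result beyond the scatter, towards a weaker inhibitor. Nothing in the data shown accounts for this step.

From the compounds shown here alone, with only this one substituent at this one position to read, it stays open whether the step belongs to fluoro itself or would also follow a chloro, a methyl or a methoxy placed there. Also open, going by these compounds, is how the result would respond to fluoro on the other carbons of that ring, or to the benzyl giving way to a longer chain or an amine.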